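The compounds below may be only part of what the source reports. "The series", "measured", "known", "first", "only" and "open" are said of these compounds alone.

Measured so far:
compound 1 `Cc1nc(N2CCC(O)(C3CC3)CC2)nc2ccc(NC(=O)/C=C/c3ccc(C(F)(F)F)cc3)cc12` — 83 nM
compound 2 `Cc1nc(N2CCC(N3CCOC3=O)CC2)nc2ccc(NC(=O)/C=C/c3ccc(OC(F)(F)F)cc3)cc12` — 31 nM

For the measured compounds named here, in a functional assay on CHO-K1 cells for antagonist activity at melanin-concentrating hormone receptor 1 (Homo sapiens), read by inositol phosphate accumulation, with stated times of 10 min and 45 min (a higher number here means a weaker inhibitor, a lower number a stronger inhibitor), compound 2 stands at the lower of the two numbers; compound 1 sits higher, beyond the scatter, but the two differ at more than one place, so no single step is attributable. Compound 3 `Cc1nc(N2CCC(N3CCCC3=O)CC2)nc2ccc(NC(=O)/C=C/c3ccc(OC(F)(F)F)cc3)cc12` is the next entry, differing from compound 2 as 2-oxopyrrolidin-1-yl in place of 2-oxo-1,3-oxazolidin-3-yl on a saturated ring carbon. Going by the values given here, no measured pair isolates this change, so the expected step in this assay is small, likely within the scatter, with no firm direction. Compound 3 is estimated at 35 nM, range 12 nM to 110 nM. The expected step of a 1.1-fold higher number from compound 2 to compound 3 (0.05 log units; within the scatter) is therefore put near zero.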

Compound 3, half-maximal inhibitory concentration: 12 nM
Beside the measured number, compound 3's estimate is 2.9-fold (0.46 log units) above it; low and high end bracket the measured number.
By their numbers in this assay, from the lowest: compound 3; then compound 2; then compound 1.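

In this assay, for the compounds shown here, 2-oxopyrrolidin-1-yl in place of 2-oxo-1,3-oxazolidin-3-yl on a saturated ring carbon gives a 2.6-fold lower number from compound 2 to compound 3 (0.41 log units; beyond the scatter), the first step that can be read at a single place. Both groups hold 6 heavy atoms and one five-membered non-aromatic ring, so this position responds to a change within the ring, not only to a change of ring size or group size. No measurement here bears on the reason for this step. Still open, from the compounds shown here alone, is whether an open-chain amide, a six-membered lactam or a basic amine on the same ring carbon would keep the number this low.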